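Appending a (3-fluorobenzyl)oxy group to the aniline of compound 1

The source may report more compounds than this note shows. Statements on the series, on what has been measured and on what is new or still open speak of the compounds shown alone.

Compound 1 `CCOC(=O)c1c(C)oc2ncnc(Nc3cccc(Cl)c3)c12` was tested in a functional assay on MCF7 cells (Homo sapiens) for cytotoxicity, read by MTT assay, with a stated time of 72 h; a lower number here means a stronger inhibitor, a higher number a weaker inhibitor. In this assay compound 1 gives only a limit, > 1000000 nM, as the limit of > 1000000 nM in this assay, at which 1 of the 2 values shown sits, shows. Compound 2 `Cc1oc2ncnc(Nc3cccc(Cl)c3)c2c1C(=O)NC(C)C` differs from it in one place, isopropylamino in place of ethoxy on a carbonyl carbon, and gives 191000 nM; that step is an at least 5.2-fold lower number from compound 1 to compound 2 (0.71 log units; beyond the scatter). Compound 3 `CCOC(=O)c1c(C)oc2ncnc(Nc3ccc(OCc4cccc(F)c4)c(Cl)c3)c12` differs from compound 1 at another place: (3-fluorobenzyl)oxy in place of hydrogen on an aromatic carbon. Among the compounds with values here, no measured step touches this position, so no bearing on the expected size or direction can be drawn from the one step known. For compound 3 the expected value is 200000 nM, between 20000 nM and 2000000 nM, which would amount to an estimated step of an at least 5.0-fold lower number from compound 1 to compound 3 (0.69 log units; beyond the scatter).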

Compound 3, half-maximal inhibitory concentration: 257000 nM
For compound 3 the middle estimate is 1.3-fold (0.11 log units) below the measured one; low and high end bracket the measured number.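

In this assay, placing (3-fluorobenzyl)oxy on the aromatic carbon ortho to a chloro group gives an at least 3.8-fold lower number from compound 1 to compound 3 (0.59 log units; beyond the scatter). A second place on compound 1, apart from the carbonyl carbon, therefore also carries a step beyond the scatter. The full size of this step stays open, since compound 1 rests on a limit: the limit of > 1000000 nM in this assay, at which 1 of the 3 values shown sits.

As far as these compounds go, whether a methoxy group or an unsubstituted benzyloxy group at this place would give a similar number remains open. So does the outcome of combining (3-fluorobenzyl)oxy with isopropylamino in one compound.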